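Replacing the methoxy group of compound 2

The compounds below may be only part of what the source reports. "The series", "measured", "known", "first", "only" and "open" are said of these compounds alone.

Measured so far in an ADME assay on CCRF-CEM cells (Homo sapiens) for cytotoxicity, with a stated time of 4 days; a higher number here means that more compound is tolerated, a lower number that less compound is tolerated:
- compound 1 `CNC(=O)CCCCn1c(=O)c(C)cn([C@@H]2O[C@H](CO[Si](C)(C)C(C)(C)C)[C@@]3(OS(=O)(=O)C=C3N)[C@H]2O[Si](C)(C)C(C)(C)C)c1=O` gives 10000 nM
- compound 2 `COC(=O)n1c(=O)c(C)cn([C@@H]2O[C@H](CO[Si](C)(C)C(C)(C)C)[C@@]3(OS(=O)(=O)C=C3N)[C@H]2O[Si](C)(C)C(C)(C)C)c1=O` gives > 100000 nM (a limit)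
- compound 3 `COC(=O)CCCC(=O)n1c(=O)c(C)cn([C@@H]2O[C@H](CO[Si](C)(C)C(C)(C)C)[C@@]3(OS(=O)(=O)C=C3N)[C@H]2O[Si](C)(C)C(C)(C)C)c1=O` gives 9900 nM

Compound 2 gives > 100000 nM in this assay as a limit and not a number. Of the three compounds, it is the only one recorded this way.

Still unmeasured is compound 4 `Cc1cn([C@@H]2O[C@H](CO[Si](C)(C)C(C)(C)C)[C@@]3(OS(=O)(=O)C=C3N)[C@H]2O[Si](C)(C)C(C)(C)C)c(=O)n(C(=O)CCCC(N)=O)c1=O`, which differs from compound 2 as follows: 3-carbamoylpropyl in place of methoxy on a carbonyl carbon. In words, 3-carbamoylpropyl stands in place of methoxy on a carbonyl carbon.

The closest measured change also replaces methoxy on a carbonyl carbon, here with 3-(methoxycarbonyl)propyl, and it gives an at least 10-fold lower number from compound 2 to compound 3 (1.00 log units; beyond the scatter). The other step involving compound 2 points the same way when read in reverse: an at least 10-fold higher number from compound 1 to compound 2 (1.00 log units; beyond the scatter). Both sizes are lower bounds. The two compounds with numerical values sit together, with a 1.0-fold lower number from compound 1 to compound 3 (0.00 log units; within the scatter).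

On the strength of compound 3 at 9900 nM, a drop of similar size is expected from compound 2 in this assay, well beyond the scatter. The expected change is an at least 8.3-fold lower number from compound 2 to compound 4 (0.92 log units; beyond the scatter). For compound 4 the estimated value is 12000 nM, with an expected range from 4000 nM to 50000 nM in this read-out.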

Compound 4, half-maximal cytotoxic concentration: 8700 nM
For compound 4 the middle estimate is 1.4-fold (0.14 log units) above the measured one; low and high end bracket the measured number.
By their numbers in this assay, from the lowest: compounds 4, 3 and 1 (each within the scatter of the next). At a limit, above all of these: compound 2.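

In this assay, amino in place of methoxy on a carbonyl carbon at the far end of the chain gives a 1.1-fold lower number from compound 3 to compound 4 (0.06 log units; within the scatter), which shows that swapping the terminal ester for a primary amide makes no readable difference. The large step seen with the ester-ended chain also holds for this second chain end, with 3-carbamoylpropyl in place of methoxy on a carbonyl carbon giving an at least 11-fold lower number from compound 2 to compound 4 (1.06 log units; beyond the scatter). The carbonyl-linked amide chain also sits with the chain attached directly to the aromatic nitrogen, as (3-carbamoylpropyl)carbonyl in place of 4-(methylcarbamoyl)butyl on an aromatic nitrogen gives a 1.1-fold lower number from compound 1 to compound 4 (0.06 log units; within the scatter), leaving compound 2 as the only one of the four apart from the rest.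

As far as these compounds go, the true size of every step from compound 2 stays open, and each can be read only as a lower bound: the limit of > 100000 nM in this assay, at which 1 of the 4 values shown sits. It also remains open whether a carboxylic acid or an amine at the chain end, or a shorter or longer chain on the carbonyl carbon, would stay with compound 1, compound 3 and compound 4 or move towards compound 2.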